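Swapping Chloro for Methyl on an Aryl Ring

The source may report more compounds than this note shows. Statements on the series, on what has been measured and on what is new or still open speak of the compounds shown alone.

Compound 1 `N#Cc1c(Nc2cccc(Cl)c2)nc(SCc2cn(Cc3ccccc3Cl)nn2)nc1-c1ccccc1` was tested in a functional assay on B16-F10 cells (Mus musculus) for inhibition, read by MTT assay, with a stated time of 72 h (on this read-out higher numbers stand for weaker inhibition and lower numbers for stronger inhibition), where compound 1 gives 3590 nM. Compound 2 `Cc1cccc(Nc2nc(SCc3cn(Cc4ccccc4Cl)nn3)nc(-c3ccccc3)c2C#N)c1` carries the change (methyl in place of chloro on an aromatic carbon); in this assay compound 2 gives 13500 nM, so the change made a 3.8-fold higher number from compound 1 to compound 2 (0.58 log units; beyond the scatter). Compound 3 `Cc1ccccc1Nc1nc(SCc2cn(Cc3ccc(Cl)cc3)nn2)nc(-c2ccccc2)c1C#N` has a core whose difference from the core of compound 1 is not broken down here. In this assay compound 3 reaches only a limit of the assay, not a number, at > 64000 nM (the limit of > 64000 nM in this assay, at which 1 of the 3 values shown sits). Compound 4 `Cc1ccc(Cn2cc(CSc3nc(Nc4ccccc4C)c(C#N)c(-c4ccccc4)n3)nn2)cc1` differs from compound 3 by methyl in place of chloro on an aromatic carbon. This is the same kind of change as the one seen before, not the same, since there the group sits meta to a large group and here para to a large group. Compound 4 is expected to show a step that the limit leaves unreadable from compound 3 to compound 4, an expectation resting on the earlier step of a 3.8-fold higher number from compound 1 to compound 2 (0.58 log units; beyond the scatter). For compound 4 the estimate in this assay is 120000 nM, expected to fall between 40000 nM and 400000 nM.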

Compound 4, half-maximal inhibitory concentration: > 64000 nM
Compound 4: a limit, no number (the forecaster's own chance of this, stated with the estimate: 85%); the middle value is on the limit's open side.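

Compound 3 and compound 4 both reach only a limit of the assay, not a number, so no step can be read between them: the limit of > 64000 nM in this assay, at which 2 of the 4 values shown sit.

On these data alone, whether 4-methylbenzyl in place of 4-chlorobenzyl changes inhibition here, as the similar change did from compound 1 to compound 2, stays open.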